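Series notes: from compound 2 to the unmeasured compound 4

A few compounds are considered here, and "the series" means these few. Any claim that something is new, unique, unknown or untested is made for them only; others in the source may bear on it.

The three measured compounds share one core, seen in compound 1 `N#Cc1ccc(C2OCC(C/C=C\CCC(=O)O)C(c3cccnc3)O2)cc1`, compound 2 `CC(C)(C)c1ccc(OC(C)(C)C2OCC(C/C=C\CCC(=O)O)C(c3cccnc3)O2)cc1` and compound 3 `COc1ccc(SC(C)(C)C2OCC(C/C=C\CCC(=O)O)C(c3cccnc3)O2)c([N+](=O)[O-])c1`. In an assay for inhibition of Thromboxane-A synthase (Homo sapiens), using microsomes (a lower number here means a stronger inhibitor, a higher number a weaker inhibitor), compound 1 gives 24 nM and compound 3 gives 40 nM; compound 2 gives 280 nM, the highest of the three numbers, beyond the scatter against both. Compound 4 `CC(C)(Cc1ccc(F)cc1)C1OCC(C/C=C\CCC(=O)O)C(c2cccnc2)O1` is not yet measured. It differs from compound 2 in one place: 4-fluorobenzyl in place of 4-(tert-butyl)phenoxy on a saturated chain carbon bound to two saturated chain carbons and a saturated ring carbon. Among the compounds with values here, no measured pair shows this change, so its size is unknown. Compounds 1 and 3, carrying different substituents on the core, give far lower numbers. On this basis the expected step is a 2.8-fold lower number from compound 2 to compound 4 (0.45 log units; beyond the scatter). For compound 4 the estimate in this assay is 100 nM, within 30 nM to 400 nM.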

Compound 4, half-maximal inhibitory concentration: 45 nM
Compound 4: middle estimate off by 2.2-fold (0.35 log units), on the high side; measured number inside the range.
By their numbers in this assay, from the lowest: compounds 1, 3 and 4 (each within the scatter of the next); then compound 2.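

In this assay, within the data shown here, 4-fluorobenzyl in place of 4-(tert-butyl)phenoxy on a saturated chain carbon bound to two saturated chain carbons and a saturated ring carbon gives a 6.2-fold lower number from compound 2 to compound 4 (0.79 log units; beyond the scatter) as the first measured step at this position, so the number here depends on the group carried there. The entering group has fewer heavy atoms and no hydrogen-bond acceptor, and this single pair cannot separate those differences. No available data explain the step.

Open, as far as these compounds go, is whether the ring substituent or the link to the ring carries the step. Plain benzyl, 4-(tert-butyl)benzyl and 4-fluorophenoxy at this position would separate the two.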